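The source may report more compounds than this note shows. Statements on the series, on what has been measured and on what is new or still open speak of the compounds shown alone.

Working notes on the series. Three compounds have numbers in an assay on BHK21 (C13) cells (Mesocricetus auratus) for inhibition of thymidine kinase, cytosolic (Cricetulus griseus), using Lineweaver-Burk analysis; a lower number here means a stronger inhibitor, a higher number a weaker inhibitor: compound 1 `CCCCCn1c(=O)c(C)cn([C@H]2C[C@H](O)[C@@H](CO)O2)c1=O` gives 72000 nM, compound 3 `CC(=O)N(C)CCN(C)C[C@H]1O[C@@H](n2cc(C)c(=O)[nH]c2=O)C[C@@H]1O` gives 900000 nM, and compound 2 `CC(=O)NC[C@H]1O[C@@H](n2cc(C)c(=O)[nH]c2=O)C[C@@H]1O` gives 6500000 nM. Compound 2 therefore stands with the highest number of the three; compound 3 lies nearest, compound 1 furthest, both gaps beyond the scatter. Within the data shown here, no single-point step between measured compounds is available. Compound 4 `Cc1cn([C@H]2C[C@H](O)[C@@H](CSCCC(=O)O)O2)c(=O)[nH]c1=O` is not yet measured; it differs from compound 2 by (2-carboxyethyl)sulfanyl in place of acetamido on a saturated chain carbon bound to a saturated ring carbon. Among the measured compounds shown here, with no measured step of this kind to lean on, the expectation for compound 4 in this assay is a modest move toward a lower number, a 3.3-fold lower number from compound 2 to compound 4 (0.51 log units; beyond the scatter), and the estimate is 2000000 nM, with a range from 300000 nM to 10000000 nM.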

Compound 4, inhibition constant: 500000 nM
The estimate for compound 4 lay 4.0-fold (0.60 log units) above the measured number; the measured number falls inside the stated range.
By their numbers in this assay, from the lowest: compound 1; then compounds 4 and 3 (each within the scatter of the next); then compound 2.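

In this assay, among these compounds, (2-carboxyethyl)sulfanyl in place of acetamido on a saturated chain carbon bound to a saturated ring carbon gives a 13-fold lower number from compound 2 to compound 4 (1.11 log units; beyond the scatter), the first single-point reading at this position. The group carried at this place therefore moves the number by a large step, beyond the scatter. No measurement available bears on the cause of this step. Whether the sulfur or the carboxylic acid accounts for the step stays open. A plain propylsulfanyl group, or a longer chain ending in the carboxylic acid, would separate the two.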